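Adding an Amino Group to the Chain of Compound 1

A few compounds are considered here, and "the series" means these few. Any claim that something is new, unique, unknown or untested is made for them only; others in the source may bear on it.

Compound 1 `CCOc1cc(-c2cccnc2)ccc1C(N)=O` is the starting point. Going by the values given here, in an assay on cells for inhibition of MAP kinase-interacting serine/threonine-protein kinase 1 (Homo sapiens), read by mobility shift assay, with stated times of 10 min and 60 min, in the presence of a further agent that is not named here (on this read-out higher numbers stand for weaker inhibition and lower numbers for stronger inhibition), compound 1 gives 2200 nM, the highest of the three numbers known here, so it is the weakest inhibitor of the set. Compound 2 `CC(C)Oc1cc(-c2cncc(-c3cnn(C4COC4)c3)c2)ccc1C(N)=O` gives 200 nM and compound 3 `CC(C)Oc1cc(-c2cncc(-c3cnn(C(C)C)c3)c2)ccc1C(N)=O` gives 85 nM; both carry an additional group that compound 1 lacks. Among the compounds with values here, the one directly comparable step, a 2.4-fold lower number from compound 2 to compound 3 (0.37 log units; beyond the scatter), concerns a change on an aromatic nitrogen and so says nothing about the saturated chain of compound 1.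

Compound 4 `NCCOc1cc(-c2cccnc2)ccc1C(N)=O` differs from compound 1 by amino in place of hydrogen on a saturated chain carbon, two bonds along the chain from an oxygen on an aromatic ring. Within the data shown here, no measured pair touches this chain, so there is no step to lean on, and the direction of any effect is unknown. With nothing pointing up or down, the expectation for compound 4 is a step of about a 1.1-fold lower number from compound 1 to compound 4 (0.04 log units; within the scatter), not beyond the scatter. Compound 4 is therefore estimated at 2000 nM in this assay, with a range from 600 nM to 7000 nM.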

Compound 4, half-maximal inhibitory concentration: 820 nM
Estimate against measurement, compound 4: 2.4-fold (0.39 log units) above; the range from low to high includes it.
By their numbers in this assay, from the lowest: compound 3; then compound 2; then compound 4; then compound 1.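

In this assay, going by these compounds alone, the change from ethoxy to 2-aminoethoxy brings a 2.7-fold lower number from compound 1 to compound 4 (0.43 log units; beyond the scatter) and gives the first reading on this chain. The step is modest, but it shows that this saturated chain carbon can carry an amino group with no loss of inhibition, and that the number moves toward stronger inhibition. No measurement here accounts for why the number falls. The compounds shown leave open whether this step depends on the amino group itself or on its place along the chain, which a hydroxyl group, a dimethylamino group or a longer chain such as 3-aminopropoxy could help to separate. On these data alone, it also remains open whether an amino group on the chain would have a similar effect on compound 2 or compound 3, which carry isopropoxy rather than ethoxy.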